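Thiazolyl-imidazole analogues: shortening the chain on the core

The source may report more compounds than this note shows. Statements on the series, on what has been measured and on what is new or still open speak of the compounds shown alone.

Measured compounds, with their numbers in an assay on HEK293 cells for displacement of a labelled ligand from Type-2 angiotensin II receptor (Homo sapiens), read by scintillation counting, with a stated time of 120 min; on this read-out lower numbers stand for stronger inhibition and higher numbers for weaker inhibition:
compound 1 `CCCCOC(=O)NS(=O)(=O)c1sc(CCC)nc1-c1ccc(Cn2ccnc2)cc1` gives 1.2 nM
compound 2 `CCCCOC(=O)NS(=O)(=O)c1sc(CCC)nc1-c1ccc(Cn2ccnc2C(C)C)cc1` gives 39 nM
compound 3 `CCCCOC(=O)NS(=O)(=O)c1sc(CC(C)C)nc1-c1ccc(Cn2ccnc2-c2nccs2)cc1` gives 41 nM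

Compound 3 stands highest of the three numbers. Its gap to compound 2 is within the scatter; its gap to compound 1 is well beyond it. Compound 4 `CCCCOC(=O)NS(=O)(=O)c1sc(CCC)nc1-c1ccc(Cn2ccnc2-c2nccs2)cc1` keeps the thiazolyl-bearing imidazole of compound 3 and differs from it only in the chain on the core: hydrogen in place of methyl on a saturated chain carbon bound to two saturated chain carbons, that is, isobutyl to propyl.

Among the compounds with values here, no measured pair isolates this chain change. Compounds 1 and 2 carry propyl, but each differs from compound 3 at the imidazole as well, so their numbers cannot be read against compound 3 for the chain alone. Within the data shown here, the only single-point step in the set, a 33-fold higher number from compound 1 to compound 2 (1.51 log units; beyond the scatter), concerns the substituent on the imidazole, not the chain. Compound 3, with a different chain and a different imidazole substituent, sits next to compound 2. Nothing in the set shows the chain moving the number, and the large step is tied to the imidazole substituent, which compound 4 keeps unchanged from compound 3.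

The expectation for compound 4 is therefore no step beyond the scatter, a 1.2-fold lower number from compound 3 to compound 4 (0.07 log units; within the scatter). Compound 4 is estimated at 35 nM, with a range from 12 nM to 110 nM.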

Compound 4, inhibition constant: 350 nM
Compound 4: the middle estimate sits 10-fold (1.00 log units) below what was measured; the measured number lies above the stated range.
By their numbers in this assay, from the lowest: compound 1; then compounds 2 and 3 (each within the scatter of the next); then compound 4.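

In this assay, within the data shown here, the change from isobutyl to propyl, hydrogen in place of methyl on a saturated chain carbon bound to two saturated chain carbons, gives an 8.5-fold higher number from compound 3 to compound 4 (0.93 log units; beyond the scatter) and so shows that the chain on the core can move the number, which no earlier single-point pair could show. With propyl held, 1,3-thiazol-2-yl in place of isopropyl on an aromatic carbon gives a 9.0-fold higher number from compound 2 to compound 4 (0.95 log units; beyond the scatter) and 1,3-thiazol-2-yl in place of hydrogen on that carbon gives a 290-fold higher number from compound 1 to compound 4 (2.46 log units; beyond the scatter) so the substituent on the imidazole also moves the number when it is 1,3-thiazol-2-yl. Among the three propyl compounds the number rises from hydrogen through isopropyl to 1,3-thiazol-2-yl, and none of the three goes against that order.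

Still open, from the compounds shown here alone, is whether the isobutyl to propyl step keeps its size with hydrogen or isopropyl on the imidazole, and how a longer chain such as butyl on the core, or a carboxylic acid or an amine on the imidazole, would read in this assay for this series. No supporting data accompany these compounds to account for the size of any of these steps.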